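Swapping an isopropyl for a chloropyridinyl on the anilino side chain

The compounds below may be only part of what the source reports. "The series", "measured", "known", "first", "only" and "open" are said of these compounds alone.

Three compounds share one core. Compound 1 `CC(=O)Nc1ccc(NC(=O)c2cc(Cl)ccc2O)c(Cl)c1` has no result in an ADME assay on A549 cells (Homo sapiens) for cytotoxicity, read by resazurin assay, with a stated time of 48 h (on this read-out lower numbers stand for higher toxicity in this test and higher numbers for lower toxicity in this test), recorded as "not determined" (no result reported). Compound 2 `CC(C)CNc1ccc(NC(=O)c2cc(Cl)ccc2O)c(Cl)c1` gives 60000 nM in this assay, the highest of the two numbers at hand, and compound 3 `O=C(Nc1ccc(NCc2ccc(F)cc2)cc1Cl)c1cc(Cl)ccc1O` gives 54400 nM, so the two stand within the scatter of each other.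

Compound 4 `O=C(Nc1ccc(NCc2cccnc2Cl)cc1Cl)c1cc(Cl)ccc1O` is not yet measured. It differs from compound 2 in one place: 2-chloropyridin-3-yl in place of isopropyl on a saturated chain carbon bound to a nitrogen on an aromatic ring. Within the data shown here, the only measured step that resembles this change is the one from compound 2 to compound 3, which also put an aromatic ring in place of the isopropyl at this position and read a 1.1-fold lower number from compound 2 to compound 3 (0.04 log units; within the scatter). That step did not move the number beyond the scatter.

On this basis compound 4 is expected to stay close to compound 2 in this assay, and the estimated step is a 1.1-fold lower number from compound 2 to compound 4 (0.04 log units; within the scatter), amounting to no shift beyond the scatter. The estimate for compound 4 is therefore 55000 nM, with a range from 25000 nM to 120000 nM.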

Compound 4, half-maximal cytotoxic concentration: 101000 nM
Estimate against measurement, compound 4: 1.8-fold (0.26 log units) below, within the range that was stated.
By their numbers in this assay, from the lowest: compounds 3, 2 and 4 (each within the scatter of the next).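

In this assay the place on a saturated chain carbon bound to a nitrogen on an aromatic ring now carries three different groups, and a 1.7-fold higher number from compound 2 to compound 4 (0.23 log units; within the scatter) and a 1.9-fold higher number from compound 3 to compound 4 (0.27 log units; within the scatter) both leave the numbers within the scatter. The earlier step covered only isopropyl and 4-fluorophenyl, whereas compound 4 shows that a 2-chloropyridin-3-yl, with its ring nitrogen and its hydrogen-bond acceptor, also gives no step beyond the scatter. Nothing measured here offers a reason for this result.

On these data alone, whether a carboxylic acid or a primary amine at this place would also stay within the scatter remains open. The same question stands for a longer chain such as hexyl, which would show whether this place tolerates more than the groups seen so far.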